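The source may hold more compounds than are shown below. What is called first, only, known or untested is meant among the compounds shown, and "the series" means these compounds.

Of the compounds shown here, two have so far been tested in an ADME assay on Huh-7 cells (Homo sapiens) for cytotoxicity, with a stated time of 3 days; on this read-out higher numbers stand for lower toxicity in this test and lower numbers for higher toxicity in this test. Compound 1 (`CCOc1ccccc1NC(=O)c1c(NCCO)cc(-c2cccc(Br)c2)oc1=O`) gives > 20000 nM, which is a limit and not a number. Compound 2 (`O=C(Nc1ccc(Br)cc1)c1c(NCCO)cc(-c2ccc(Br)cc2)oc1=O`) gives > 20000 nM, which is likewise a limit. Compound 2 thus has no exact place on the scale, and the whole record is the limit of > 20000 nM in this assay, at which 2 of the 2 values shown sit.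

Compound 3 (`CCOc1ccccc1NC(=O)c1c(NCCO)cc(-c2ccc(Br)cc2)oc1=O`) has not yet been measured. It keeps the core of compound 2 and has 2-ethoxyphenyl in place of 4-bromophenyl on an amide-type nitrogen. Compound 1 also carries 2-ethoxyphenyl on an amide-type nitrogen, and its value is the limit > 20000 nM. For the measured compounds named here, no measured step yet shows the effect of this exchange, so the expectation rests on these two limits alone. The step that the limit leaves unreadable from compound 2 to compound 3 is expected to stay within the usual scatter, with no clear direction, and a further limit is the likeliest report. For compound 3 the estimated value in this assay is 25000 nM, with an expected range from 12000 nM to 45000 nM.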

Compound 3, half-maximal cytotoxic concentration: > 20000 nM
Compound 3 was reported as a limit; the forecaster's own chance of this, stated with the estimate: 85%; the middle value is on the limit's open side.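

No step from compound 1 or compound 2 to compound 3 can be read, as compound 3 is also reported only as a limit: the limit of > 20000 nM in this assay, at which 3 of the 3 values shown sit.

The compounds shown leave open how far each one lies from that limit, and whether either exchange of groups alters the half-maximal cytotoxic concentration at all.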